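From methoxy to ethoxycarbonyl: compound 3 to compound 4

The source may hold more compounds than are shown below. What is called first, only, known or untested is meant among the compounds shown, and "the series" means these compounds.

For the measured compounds named here, in a functional assay on MDA-MB-231 cells (Homo sapiens) for antiproliferative activity, read by MTT assay, with a stated time of 72 h (on this read-out lower numbers stand for stronger inhibition and higher numbers for weaker inhibition), compound 3 (`COc1ccc(NC(=O)CCc2cccc3c2B(O)OC3)cc1`) gives 850 nM and holds the lowest of the three numbers so far. On the same core, compound 1 (`C#Cc1ccc(NC(=O)CCc2cccc3c2B(O)OC3)cc1`) gives 6600 nM and compound 2 (`CC(C)(C)c1ccc(NC(=O)CCc2cccc3c2B(O)OC3)cc1`) gives 33000 nM in this read-out.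

Compound 4 (`CCOC(=O)c1ccc(NC(=O)CCc2cccc3c2B(O)OC3)cc1`) has not yet been measured. It carries ethoxycarbonyl in place of methoxy on an aromatic carbon, para to a large group (ethoxycarbonyl in place of methoxy on an aromatic carbon).

Three measured steps change the group at this place. Two of them end on methoxy and both lower the number: one modest (a 7.8-fold lower number from compound 1 to compound 3 (0.89 log units; beyond the scatter)) and one large (a 39-fold lower number from compound 2 to compound 3 (1.59 log units; beyond the scatter)). The third is modest (a 5.0-fold higher number from compound 1 to compound 2 (0.70 log units; beyond the scatter)). Leaving methoxy therefore has only these two precedents, compound 1 and compound 2, and both stand higher. Neither of them holds a carbonyl, so the data give no direct guide to ethoxycarbonyl. A rise of modest size is expected in this assay rather than a large one. The estimated step is a 4.7-fold higher number from compound 3 to compound 4 (0.67 log units; beyond the scatter) and its size remains uncertain. For compound 4 the estimated value is 4000 nM (range 1200 nM to 16000 nM).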

Compound 4, half-maximal inhibitory concentration: > 100000 nM
Compound 4 was reported as a limit; the forecaster's own chance of this, stated with the estimate: 5%; at least 25-fold (1.39 log units) between middle value and limit.
By their numbers in this assay, from the lowest: compound 3; then compound 1; then compound 2. At a limit, above all of these: compound 4.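

In this assay compound 4 is reported as a limit and not as a number: > 100000 nM. Ethoxycarbonyl, the only group of the four at this aromatic carbon that holds a carbonyl, gives an at least 110-fold higher number from compound 3 to compound 4 (2.07 log units; beyond the scatter), and it also stands apart from the other two groups, with an at least 15-fold higher number from compound 1 to compound 4 (1.18 log units; beyond the scatter) and an at least 3.0-fold higher number from compound 2 to compound 4 (0.48 log units; beyond the scatter). Exchange at this one place, para to a large group, now spans the series from its lowest number to the limit, so the position is more sensitive than the three earlier compounds showed, and each of these steps gives only a lower bound on the gap: the limit of > 100000 nM in this assay, at which 1 of the 4 values shown sits.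

The compounds shown leave open whether the carbonyl or the ethyl part of the ester goes with this rise. A carboxylic acid or a primary amide at this place would keep the carbonyl without the ethyl part, and ethoxy would keep the ethyl part on oxygen without the carbonyl.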